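The source may hold more compounds than are shown below. What is called first, only, known or untested is meant among the compounds shown, and "the series" means these compounds.

In a functional assay on A549 cells (Homo sapiens), read by MTT assay, with a stated time of 72 h (on this read-out lower numbers stand for stronger inhibition and higher numbers for weaker inhibition), three nucleosides have been measured, and none of them yields a number. Compound 1 `Cc1ncnc2c1c(-c1cccs1)cn2[C@@H]1O[C@H](CO)[C@@H](O)[C@H]1O` gives > 20000 nM as a limit only. Compound 2 `COc1nc(N)nc2c1c(-c1ccco1)cn2[C@@H]1O[C@H](CO)[C@@H](O)[C@H]1O` gives > 20000 nM as a limit only. Compound 3 `Nc1nc2c(c(-c3ccco3)cn2[C@@H]2O[C@H](CO)[C@@H](O)[C@H]2O)c(=O)[nH]1` likewise stands at > 20000 nM as a limit and not a number. Within the data shown here, the record so far is thus the limit of > 20000 nM in this assay, at which 3 of the 3 values shown sit, and shows no measured step. Compound 4 `Nc1nc2c(c(-c3ccsc3)cn2[C@@H]2O[C@H](CO)[C@@H](O)[C@H]2O)c(=O)[nH]1` carries thiophen-3-yl in place of furan-2-yl on an aromatic carbon. With nothing but the limit of compound 3 to go on, no change beyond the scatter is expected in this assay in either direction, and the expected step is a number no higher from compound 3 to compound 4 (the limit leaves the size open) in size. Compound 4 is estimated at 20000 nM with an expected range of 6000 nM to 40000 nM as its likely span.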

Compound 4, half-maximal inhibitory concentration: > 20000 nM
Compound 4 was reported as a limit; the forecaster's own chance of this, stated with the estimate: 75%; the middle value lies on the limit itself.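

Compound 3 and compound 4 are both reported only as limits, not numbers, so no step can be read between them. The compounds shown leave open how strongly any of them acts in this assay, and whether thiophen-3-yl and furan-2-yl differ at all.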